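Cyclopentylamino in Place of Hexylsulfanyl: Cytotoxicity Outlook

The compounds below may be only part of what the source reports. "The series", "measured", "known", "first", "only" and "open" are said of these compounds alone.

Compound 1 `CCCOc1nc(N)nc2c1ncn2/C=C1/CC1(CO)CO` gives > 20000 nM in an ADME assay on BCBL1 cells (Homo sapiens) for cytotoxicity, with a stated time of 7 days (on this read-out higher numbers stand for lower toxicity in this test and lower numbers for higher toxicity in this test), a limit of the assay.
Compound 2 `Nc1nc(OCC(F)(F)F)c2ncn(/C=C3/CC3(CO)CO)c2n1` gives > 20000 nM in this assay, a limit of the assay.
Compound 3 `CCCCCCSc1nc(N)nc2c1ncn2/C=C1/CC1(CO)CO` gives > 20000 nM in this assay, a limit of the assay.

Compound 3 stands where every measured compound here stands, at the limit of > 20000 nM in this assay, at which 3 of the 3 values shown sit, so no number sets it apart from the other two. The steps between the measured compounds are a step that the two limits leave unreadable from compound 1 to compound 2, a step that the two limits leave unreadable from compound 1 to compound 3 and a step that the two limits leave unreadable from compound 2 to compound 3. Compound 4 `Nc1nc(NC2CCCC2)c2ncn(/C=C3/CC3(CO)CO)c2n1` differs from compound 3 in one place: cyclopentylamino in place of hexylsulfanyl on an aromatic carbon. Among the compounds with values here, none of the measured steps involves a cyclopentylamino group, and none has a readable size; together they show only that propoxy, 2,2,2-trifluoroethoxy and hexylsulfanyl on an aromatic carbon all leave the read-out at its limit. The expected step is therefore a step that the limit leaves unreadable from compound 3 to compound 4, with no direction beyond the scatter that the data could support. Compound 4 is estimated at 25000 nM in this assay, with a range from 8000 nM to 80000 nM, and it is expected most likely to be reported once more only as a limit.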

Compound 4, half-maximal cytotoxic concentration: 71700 nM
The estimate for compound 4 lay 2.9-fold (0.46 log units) below the measured number; measured number inside the range.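

Within the data shown here, compound 4 now carries a number, but compounds 1, 2 and 3 stay limits of the assay, so no step from any of them to compound 4 can be read: the limit of > 20000 nM in this assay, at which 3 of the 4 values shown sit. The compounds shown leave open whether cyclopentylamino in place of hexylsulfanyl, propoxy or 2,2,2-trifluoroethoxy changes the read-out in this assay at all, and in which direction.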